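Thioether aryl swap: from compound 3 to compound 4

This account rests on a few compounds, and the source may have more. Where it says the series, first, only, none or still open, it means among the compounds named here.

Compound 1 `Cc1cc(Nc2cc(-c3cccs3)[nH]n2)n2nc(SCc3ccc(Br)cc3)nc2n1`: 38700 nM in an ADME assay on GES1 cells (Homo sapiens) for inhibition, read by MTT assay, with a stated time of 72 h; a higher number here means a weaker inhibitor, a lower number a stronger inhibitor.
Compound 2 `CCCCCc1c(C)nc2nc(SCc3ccc(Cl)cc3)nn2c1Nc1cc(-c2ccccc2)[nH]n1`: the value in this assay is a limit, > 50000 nM.
Compound 3 `Cc1cc(Nc2cc(-c3ccccc3)[nH]n2)n2nc(SCc3ccccc3Br)nc2n1`: 41100 nM in this assay.

Among the measured compounds shown here, the numbers so far are all weak. In this assay compound 3 and compound 1 lie within the usual scatter of each other, so neither can be set above the other. Compound 2 gives only a limit, which is where one of the three values sits (the limit of > 50000 nM in this assay, at which 1 of the 3 values shown sits).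

Compound 4 `Cc1cc(Nc2cc(-c3ccccc3)[nH]n2)n2nc(SCc3csc4ccccc34)nc2n1` carries the change (1-benzothiophen-3-yl in place of 2-bromophenyl on a saturated chain carbon bound to a sulfur). For the measured compounds named here, no measured pair shows what such a change does, so for the step of a 1.0-fold lower number from compound 3 to compound 4 (0.01 log units; within the scatter) the expectation is no change beyond the scatter. Compound 4 is therefore expected at about 40000 nM, between 15000 nM and 100000 nM, with a fair chance that only a limit is reported.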

Compound 4, half-maximal inhibitory concentration: 29200 nM
Compound 4: the middle estimate sits 1.4-fold (0.14 log units) above what was measured, within the range that was stated.
By their numbers in this assay, from the lowest: compounds 4, 1 and 3 (each within the scatter of the next). At a limit, above all of these: compound 2.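

In this assay the swap of 2-bromophenyl for 1-benzothiophen-3-yl on a saturated chain carbon bound to a sulfur gives a 1.4-fold lower number from compound 3 to compound 4 (0.15 log units; within the scatter) and is the only step shown at this place. Neither aryl group can be set above the other, and both compounds remain weak in this read-out. Nothing measured here accounts for the step. As far as these compounds go, whether a group of another kind at this place, such as an amine or a carboxylic acid on a longer chain, would move the number beyond the scatter remains open.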